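From 3-methylphenyl to 2-fluorophenyl on a shared core

A few compounds are considered here, and "the series" means these few. Any claim that something is new, unique, unknown or untested is made for them only; others in the source may bear on it.

Two related compounds have so far been measured in a physicochemical assay for solubility, read by turbidimetry, measured as kinetic solubility, at pH 6.8; on this read-out higher numbers stand for higher solubility and lower numbers for lower solubility. In this test, compound 1 `CC1SC(c2cccc(C(=O)NCCCCc3ccccc3)c2)N(c2ccc(C3CC3)cc2)C1=O` gives 10000 nM. Compound 2 `Cc1cccc(N2C(=O)CSC2c2cccc(C(=O)NCCCCc3ccccc3)c2)c1` gives 10000 nM, which places it level with compound 1, within the usual scatter of repeated measurements. Compound 3 `O=C(NCCCCc1ccccc1)c1cccc(C2SCC(=O)N2c2ccccc2F)c1` has not yet been measured. It carries 2-fluorophenyl in place of 3-methylphenyl on an amide-type nitrogen in a ring. Among the compounds with values here, no measured pair shows what a single change does here, so the estimate rests on compound 2 at 10000 nM and on compound 1 reading the same. In this assay, the expected result is no step beyond the scatter in either direction, with an estimated no change at the digits printed from compound 2 to compound 3 (within the scatter). Compound 3 is expected to read about 10000 nM, with an estimated range of 5000 nM to 20000 nM.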

Compound 3, solubility: 20000 nM
For compound 3 the middle estimate is 2.0-fold (0.30 log units) below the measured one, and the stated range covers the measured number.
By their numbers in this assay, from the lowest: compounds 1, 2 and 3 (each within the scatter of the next).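

In this assay, within the data shown here, the exchange of 3-methylphenyl for 2-fluorophenyl on the amide-type nitrogen in the ring gives a 2.0-fold higher number from compound 2 to compound 3 (0.30 log units; within the scatter) and is the first single change that can be read at this position. On this evidence the two groups cannot be told apart at this place on this read-out, as the step does not go beyond the usual scatter. No measurement here offers an explanation for how close the two readings are.

The compounds shown leave open whether a quite different group at this place, such as a pyridine ring or a phenyl ring carrying an amine or a carboxylic acid, would produce a step beyond the scatter. They also leave open what a shorter chain on the amide would do on the same core.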